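Changing the Aryl Group on a Shared Acrylic Acid Core

The compounds below may be only part of what the source reports. "The series", "measured", "known", "first", "only" and "open" are said of these compounds alone.

Three compounds that share one core were tested in a functional assay on M14 cells (Homo sapiens) for cytotoxicity, read by MTT assay, with a stated time of 72 h; a higher number here means a weaker inhibitor, a lower number a stronger inhibitor. Compound 1 `COc1cc(/C(=C\c2cn(C(C)=O)c3ccc(OCc4ccccc4)cc23)C(=O)O)cc(OC)c1OC` gives 57100 nM there. Compound 2 `CC(=O)n1cc(/C=C(/C(=O)O)c2ccc(OCc3ccccc3)cc2)c2cc(OCc3ccccc3)ccc21` gives 58200 nM in this assay, and these two values lie within the scatter of each other. Compound 3 `COc1ccccc1/C(=C\c1cn(C(C)=O)c2ccc(OCc3ccccc3)cc12)C(=O)O` reaches only the limit of this assay, > 100000 nM, so no number is known for it. For the measured compounds named here, the one step that touches compound 3 is an at least 1.7-fold higher number from compound 1 to compound 3 (0.24 log units; that floor lies within the scatter), and because compound 3 sits at the limit of > 100000 nM in this assay, at which 1 of the 3 values shown sits, the true size of that step stays open. Compound 3 therefore stands at the weak end of what has been measured, known only as a limit.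

Compound 4 `CC(=O)n1cc(/C=C(/C(=O)O)c2ccc(Cl)cc2)c2cc(OCc3ccccc3)ccc21` differs from compound 3 in one place: 4-chlorophenyl in place of 2-methoxyphenyl on a double-bonded chain carbon bound to a carbonyl carbon and a double-bonded chain carbon. Going by the values given here, no measured step exchanges a methoxy-bearing aryl group for a chlorine-bearing one, so the step from compound 1 to compound 3 is the only guide, and it shows that changing the aryl group at this position produced a step whose floor lies within the scatter. A step of similar size, or none beyond the scatter, is expected in this assay. Compound 4 is therefore expected to give about 80000 nM in this assay, within 40000 nM to 200000 nM, which corresponds to an expected at least 1.2-fold lower number from compound 3 to compound 4 (0.09 log units; that floor lies within the scatter).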

Compound 4, half-maximal inhibitory concentration: > 100000 nM
Compound 4: no number, only a limit; the forecaster's own chance of this, stated with the estimate: 40%; middle value at least 1.2-fold (0.09 log units) away from the limit.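

A second aryl group at this position now reaches the limit: in this assay compound 4 stands at > 100000 nM, which is a limit and not a number. Placing 4-chlorophenyl on the double-bonded chain carbon in place of 3,4,5-trimethoxyphenyl gives an at least 1.7-fold higher number from compound 1 to compound 4 (0.24 log units; that floor lies within the scatter), and chloro in place of benzyloxy on an aromatic carbon gives an at least 1.7-fold higher number from compound 2 to compound 4 (0.23 log units; that floor lies within the scatter), so neither floor shows a change beyond the scatter. The step between the two compounds at the limit cannot be read, and the true sizes of the two floors stay unknown because these compounds give limits rather than numbers: the limit of > 100000 nM in this assay, at which 2 of the 4 values shown sit.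

The compounds shown leave open how far either 2-methoxyphenyl or 4-chlorophenyl really lies from the groups that give numbers in this assay, and so whether this position responds to the aryl group at all. They also leave open whether an aryl group carrying an amine, a hydroxyl or a nitrile at this carbon, or a methyl ester in place of the carboxylic acid on the shared core, would give a number clearly apart from those of compound 1 and compound 2.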